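Pyridin-2-yl for phenyl on the free phenol core

The source may report more compounds than this note shows. Statements on the series, on what has been measured and on what is new or still open speak of the compounds shown alone.

Compound 3 `C=C1C(=O)[C@]23C[C@@]1(O)CC[C@H]2c1ccc(O)c(C)c1[C@@H]3Cn1cc(-c2ccccc2)nn1` is the free phenol of the series and in a functional assay on HL-60 cells (Homo sapiens) for cytotoxicity, read by MTT assay, with a stated time of 4 days (a lower number here means a stronger inhibitor, a higher number a weaker inhibitor), compound 3 gives 750 nM. Of the three measured numbers none is lower; the gap to compound 2 `C=C1C(=O)[C@]23C[C@@]1(O)CC[C@H]2c1ccc(OS(=O)(=O)c2ccc(C)cc2)c(C)c1[C@@H]3Cn1cc(-c2ccc(Cl)cc2)nn1`, which in this assay gives 1260 nM, lies within the usual scatter, whereas the gap to compound 1 `C=C1C(=O)[C@]23C[C@@]1(O)CC[C@H]2c1ccc(OS(=O)(=O)c2ccc(C)cc2)c(C)c1[C@@H]3Cn1cc(-c2ccccn2)nn1`, which gives 1810 nM, lies beyond it. Compounds 1 and 2 both carry the tosylated phenol.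

Compound 4 `C=C1C(=O)[C@]23C[C@@]1(O)CC[C@H]2c1ccc(O)c(C)c1[C@@H]3Cn1cc(-c2ccccn2)nn1` differs from compound 3 in one place: pyridin-2-yl in place of phenyl on an aromatic carbon.

Going by the values given here, only one measured step touches the same position, and it is on the tosylated core: a 1.4-fold lower number from compound 1 to compound 2 (0.16 log units; within the scatter). That step exchanges pyridin-2-yl for 4-chlorophenyl rather than for plain phenyl, so its bearing is indirect, but it shows that swapping the aryl on the triazole moved the number only within the scatter. Among the compounds with values here, no measured pair shows phenyl against pyridin-2-yl directly.

The expected step is therefore small: compound 4 is expected to show a 1.3-fold higher number from compound 3 to compound 4 (0.12 log units; within the scatter), a slightly higher number, likely within the scatter. Compound 4 is estimated at 1000 nM in this assay, with a range from 500 nM to 2200 nM.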

Compound 4, half-maximal inhibitory concentration: 1970 nM
The estimate for compound 4 lay 2.0-fold (0.29 log units) below the measured number; the measured number falls inside the stated range.
By their numbers in this assay, from the lowest: compounds 3, 2, 1 and 4 (each within the scatter of the next, the first and the last beyond it).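

Going by these compounds alone, this is the first direct reading of phenyl against pyridin-2-yl at this position: in this assay, on the free phenol core, the exchange gives a 2.6-fold higher number from compound 3 to compound 4 (0.42 log units; beyond the scatter), whereas the only earlier step here, a 1.4-fold lower number from compound 1 to compound 2 (0.16 log units; within the scatter), compared a different aryl pair on the tosylated core and stayed within the scatter. With pyridin-2-yl held in place, hydrogen in place of (4-methylphenyl)sulfonyl on the oxygen gives a 1.1-fold higher number from compound 1 to compound 4 (0.04 log units; within the scatter), which is within the scatter, so in this pair the free phenol brings no readable gain and the low number of compound 3 cannot be credited to the free phenol alone. Nothing at hand bears on why the swap of a ring carbon for a ring nitrogen moves the number on the free phenol core.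

Still open is whether the phenyl to pyridin-2-yl step holds on the tosylated core, since no phenyl partner with the tosyl group stands among these compounds. Also open, from the compounds shown here alone, is whether the number tracks the ring nitrogen as such or its place in the ring, a question that pyridin-3-yl or pyridin-4-yl on the same aromatic carbon would address.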